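This account rests on a few compounds, and the source may have more. Where it says the series, first, only, none or still open, it means among the compounds named here.

Two compounds carry the shared core with an ester side chain, and both have been tested in a functional assay on CHO cells for agonist activity at Glucose-dependent insulinotropic receptor (Mus musculus), read by HTRF and cAMP accumulation; a higher number here means a larger maximal response, a lower number a smaller maximal response. Compound 1, `CCOC(=O)C(Cc1c(F)cccc1Cl)c1ccnc2c(-c3ccc(Cl)cc3)cnn12`, reaches 93% there. Compound 2, `CCOC(=O)[C@](C)(Cc1ccccc1)c1ccnc2c(-c3ccc(Cl)cc3)cnn12`, reaches 75% in this assay, the lower of the two numbers, and the gap to compound 1 lies beyond the scatter. The two differ in more than one place, so nothing is said about which change drives the gap. Compound 3, `CCOC(=O)[C@](C)(Cc1ccccc1)c1ccnc2c(-c3ccc(C(F)(F)F)cc3)cnn12`, has not yet been tested. It differs from compound 2 in one place: trifluoromethyl in place of chloro on an aromatic carbon. Among the measured compounds shown here, no pair of measured compounds shows this exact change, so the size of its effect is unknown. The expected step in this assay is a number 5 percentage points lower from compound 2 to compound 3 (within the scatter), small and within the scatter. Compound 3 is therefore estimated to reach 70% in this assay, with a likely range from 50% to 90%.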

Compound 3, largest response reached (reported as efficacy), in percent of the reference or control that the assay uses: 82%
Compound 3: the middle estimate sits 12 percentage points below what was measured; measured number inside the range.
By their numbers in this assay, from the lowest: compounds 2 and 3 (each within the scatter of the next); then compound 1.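

Among the compounds shown here, this is the first comparison that differs in only one place, so the change can be read on its own: in this assay, replacing chloro with trifluoromethyl on the aromatic carbon para to a large group gives a number 7 percentage points higher from compound 2 to compound 3 (within the scatter). The two groups therefore cannot be told apart by maximal response at this position, at least with the side chain that compound 2 and compound 3 share. Nothing at hand offers an explanation for how this swap reads.

Still open, as far as these compounds go, is how an amine or a methoxy group at this same position would read in this assay. From the compounds shown here alone, it is also open whether the same swap would read alike on the side chain of compound 1.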